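From carbamoyl to hydroxymethyl in a series at the limit

The source may hold more compounds than are shown below. What is called first, only, known or untested is meant among the compounds shown, and "the series" means these compounds.

In a functional assay on cells (Platelet, Homo sapiens) for inhibition (a lower number here means a stronger inhibitor, a higher number a weaker inhibitor), compound 1 (`CCOC(=O)c1ccc(-c2nn(-c3ccco3)c3ccccc23)cc1`) gives > 10000 nM as a limit of the assay, not a number. Compound 2 (`NC(=O)c1ccc(-c2nn(Cc3ccccc3)c3ccccc23)cc1`) gives > 10000 nM in the same way, again only a limit. Compound 3 (`OCc1ccc(-c2nn(Cc3ccccc3)c3ccccc23)cc1`) carries hydroxymethyl in place of carbamoyl on an aromatic carbon, para to a large group (hydroxymethyl in place of carbamoyl on an aromatic carbon). Going by the values given here, no measured step exists to scale this change. A modest shift toward stronger inhibition in this assay is expected, an at least 1.2-fold lower number from compound 2 to compound 3 (0.09 log units; that floor lies within the scatter) by estimate. Compound 3 is estimated at 8000 nM within an expected range (1500 nM to 30000 nM) and may still read only as a limit.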

Compound 3, half-maximal inhibitory concentration: > 10000 nM
Compound 3: no number, only a limit; the forecaster's own chance of this, stated with the estimate: 50%; at least 1.2-fold (0.09 log units) between middle value and limit.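

No step can be read from compound 2 to compound 3 in this assay because both sit at one limit: the limit of > 10000 nM in this assay, at which 3 of the 3 values shown sit.

The compounds shown leave open how carbamoyl and hydroxymethyl rank, and whether any compound on this core gives a true number in this assay.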